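A few compounds are considered here, and "the series" means these few. Any claim that something is new, unique, unknown or untested is made for them only; others in the source may bear on it.

Compound 1 `COc1cc(-c2nn(-c3cccc(NC(=O)c4cccc(C(F)(F)F)c4)c3)cc2-c2ccncc2)ccc1Cl`: 1390 nM
Compound 2 `COc1cc(-c2nn(-c3cccc(NC(=O)Nc4ccc(Cl)c(C(F)(F)F)c4)c3)cc2-c2ccncc2)ccc1Cl`: 1170 nM

In a functional assay on LOX IMVI cells (Homo sapiens) for inhibition, read by sulforhodamine B assay, with a stated time of 48 h (on this read-out higher numbers stand for weaker inhibition of growth and lower numbers for stronger inhibition of growth), compound 2 gives the lower of the two numbers, yet the step of a 1.2-fold lower number from compound 1 to compound 2 (0.07 log units; within the scatter) lies within the scatter, so neither compound can be called the stronger. Compound 3 `O=C(Nc1cccc(-n2cc(-c3ccncc3)c(-c3ccc(Cl)c(O)c3)n2)c1)Nc1ccc(Cl)c(C(F)(F)F)c1` differs from compound 2 by hydrogen in place of methyl on an oxygen on an aromatic ring. Among the measured compounds shown here, no measured step touches this oxygen; the only recorded step concerns another part of the molecule and gives no guide here. For compound 3 the expected step is a 1.1-fold higher number from compound 2 to compound 3 (0.05 log units; within the scatter), nothing beyond the scatter. Compound 3 is estimated at 1300 nM, within a range of 500 nM to 3500 nM.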

Compound 3, concentration for 50% growth inhibition: 554 nM
Beside the measured number, compound 3's estimate is 2.3-fold (0.37 log units) above it, and the stated range covers the measured number.
By their numbers in this assay, from the lowest: compound 3; then compounds 2 and 1 (each within the scatter of the next).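

Within this assay, replacing methoxy with hydroxy on the 4-chloro-3-methoxyphenyl group gives a 2.1-fold lower number from compound 2 to compound 3 (0.32 log units; beyond the scatter) and is the only step here beyond the scatter, though a modest one. It shows that the group on this oxygen affects growth inhibition, whereas the earlier change on the carbonyl carbon gave no readable difference. No measurement here explains this shift.

The compounds shown leave open whether an amine or a carboxylic acid in place of the hydroxy would match compound 3. They also leave open whether the same change would give a similar step on the amide of compound 1.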